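A few compounds are considered here, and "the series" means these few. Any claim that something is new, unique, unknown or untested is made for them only; others in the source may bear on it.

Compound 1 `Cc1cc(-c2noc(COc3ccc(CCC(=O)O)cc3)n2)ccc1F` and compound 2 `O=C(O)CCc1ccc(OCc2nc(-c3cccc(Br)c3)no2)cc1` share one core and differ only in the aromatic group attached to it. In a functional assay on CHO cells for agonist activity at Free fatty acid receptor 1 (Homo sapiens), read by FLIPR and calcium flux, in the presence of a further agent that is not named here (a higher number here means that more compound is needed for the effect, a lower number that less compound is needed), compound 1 gives 2120 nM, while compound 2 gives 1260 nM in this assay. Within the data shown here, the single measured step, a 1.7-fold lower number from compound 1 to compound 2 (0.23 log units; within the scatter), shows that swapping one six-membered carbon ring for another on that aromatic carbon did not move the number beyond the scatter. Compound 2 thus holds the lower of the two numbers seen so far, but its gap to compound 1 lies within the scatter, so neither can be called the more potent. Compound 3 `O=C(O)CCc1ccc(OCc2nc(-c3cccs3)no2)cc1` is the next step from compound 2: thiophen-2-yl in place of 3-bromophenyl on an aromatic carbon. Among the measured compounds shown here, the only step that bears on this change is a 1.7-fold lower number from compound 1 to compound 2 (0.23 log units; within the scatter), which was small; no measured pair involves a five-membered ring at this carbon, so the data give no direct guide for the thiophen-2-yl group. Compound 3 is therefore expected to give about 1900 nM in this assay, with a range from 700 nM to 5500 nM. The step this estimate implies, a 1.5-fold higher number from compound 2 to compound 3 (0.18 log units; within the scatter), is expected to be a modest rise, not clearly beyond the scatter.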

Compound 3, half-maximal effective concentration: 2570 nM
For compound 3 the middle estimate is 1.4-fold (0.13 log units) below the measured one; measured number inside the range.
By their numbers in this assay, from the lowest: compounds 2, 1 and 3 (each within the scatter of the next, the first and the last beyond it).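

Among these compounds, the step of a 2.0-fold higher number from compound 2 to compound 3 (0.31 log units; beyond the scatter) in this assay is the first at this position, on the aromatic carbon between two ring nitrogen atoms, to lie beyond the scatter, although only modestly, and it comes with thiophen-2-yl in place of 3-bromophenyl. The other new step, a 1.2-fold higher number from compound 1 to compound 3 (0.08 log units; within the scatter) with thiophen-2-yl in place of 4-fluoro-3-methylphenyl, stays within the scatter, so the five-membered ring is set apart from 3-bromophenyl but not from 4-fluoro-3-methylphenyl, and the smaller ring with its sulfur atom cannot be read as a clear change in either direction. Nothing measured here explains why the number moves with this change.

The compounds shown leave open whether plain phenyl would stand with 3-bromophenyl or with thiophen-2-yl, which would show whether the bromine matters to this step. They also leave open how this carbon would respond to a saturated ring such as cyclohexyl, or to a ring carrying an amine or a carboxylic acid, as all three groups shown are uncharged aromatic rings.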